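The source may hold more compounds than are shown below. What is called first, only, known or untested is meant among the compounds shown, and "the series" means these compounds.

Of the compounds shown here, three built on one shared core have been measured. Compound 1 `CSc1ccc(C)cc1NCC1=NCCN1` gives 101% in a functional assay for agonist activity at Alpha-1A adrenergic receptor (Homo sapiens); on this read-out higher numbers stand for larger maximal responses and lower numbers for smaller maximal responses. Compound 2 `Cc1ccc(S(C)(=O)=O)c(NCC2=NCCN2)c1` gives 98% in this assay, and compound 3 `COc1ccc(SC)c(NCC2=NCCN2)c1` gives 101%. Compound 2 shows the lowest of the three numbers, yet its gaps to compound 1 and to compound 3 are both within the scatter, so the three stand level. Compound 4 `CS(=O)(=O)c1ccc(C(F)(F)F)cc1NCC1=NCCN1` differs from compound 2 by trifluoromethyl in place of methyl on an aromatic carbon. For the measured compounds named here, two steps bear on this change: a number 3 percentage points lower from compound 1 to compound 2 (within the scatter), and no change at the digits printed from compound 1 to compound 3 (within the scatter), which likewise replaced a methyl on an aromatic carbon. Since both stay within the scatter, no step beyond the scatter is expected in this assay. For compound 4 the expected value is 97%, between 85% and 106%. That estimate means a number 1 percentage points lower from compound 2 to compound 4 (within the scatter).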

Compound 4, largest response reached (reported as maximum), in percent of the reference or control that the assay uses: 95%
Compound 4: the middle estimate sits 2 percentage points above what was measured, within the range that was stated.
By their numbers in this assay, from the lowest: compounds 4, 2, 1 and 3 (each within the scatter of the next).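

In this assay, trifluoromethyl in place of methyl at the place para to a methylsulfonyl group gives a number 3 percentage points lower from compound 2 to compound 4 (within the scatter) and so leaves the maximal response level. Until now, only methoxy had replaced methyl on this aromatic carbon, in a compound carrying methylsulfanyl; a group of 4 heavy atoms now does the same in a compound carrying methylsulfonyl. On these data alone, whether an amine or a carboxylic acid at this place would also hold the response stays open. Nothing measured here gives a reason for this level response.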